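Cytotoxicity notes: aryl swap on the amide nitrogen

The source may report more compounds than this note shows. Statements on the series, on what has been measured and on what is new or still open speak of the compounds shown alone.

Compound 1 `O=C(Nc1cccc(-c2ccco2)c1)C1CCCN(C(=O)c2cc(C(F)(F)F)cc(C(F)(F)F)c2)C1` has been run in an ADME assay on PC-3 cells (Homo sapiens) for cytotoxicity, read by WST assay, tested at 100 uM; a lower number here means less inhibition, a higher number more inhibition at the concentration tested (going by the name of the read-out); compound 1 gives 0%. Compound 2 `C=Cc1cccc(C(=O)N2CCCC(C(=O)Nc3ccc(Cl)cc3)C2)c1` gives 0% in this assay, and compound 3 `O=C(Nc1cccc(Cc2ccccc2)c1)C1CCCN(C(=O)c2cc(C(F)(F)F)cc(C(F)(F)F)c2)C1` gives 0%. Compound 1 stands level with compounds 2 and 3 at the digits shown; nearest is compound 2 and furthest is compound 3, neither differing beyond the scatter. Among the compounds with values here, the one single-point step among the measured compounds, from compound 1 to compound 3, reads no change at the digits printed from compound 1 to compound 3 (within the scatter).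

Compound 4 `O=C(Nc1ccc(Cl)cn1)C1CCCN(C(=O)c2cc(C(F)(F)F)cc(C(F)(F)F)c2)C1` has not yet been measured. It differs from compound 1 by 5-chloropyridin-2-yl in place of 3-(furan-2-yl)phenyl on an amide-type nitrogen. The step from compound 1 to compound 3 bears on it, since that step also alters the group carried on the amide side of the shared core and shows no movement in this assay. Compound 2 carries yet another group on the same amide-type nitrogen and likewise shows no inhibition. Within the data shown here, no measured step therefore points to a change beyond the scatter in this assay. The expected step in this assay is no change at the digits printed from compound 1 to compound 4 (within the scatter). Compound 4 is estimated at 0%, between -8% and 10%.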

Compound 4, a percentage reported as inhibition, at one concentration (the size of the read-out at that concentration, not a potency): 0%
Beside the measured number, compound 4's estimate shows no gap at the digits printed, within the range that was stated.
By their numbers in this assay, from the lowest: compounds 1, 2, 3 and 4 (each within the scatter of the next).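

On the amide-type nitrogen, 5-chloropyridin-2-yl in place of 3-(furan-2-yl)phenyl gives no change at the digits printed from compound 1 to compound 4 (within the scatter) in this assay, so the reading holds when the whole group on this nitrogen is exchanged. The earlier step from the same parent altered only the substituent on the aromatic carbon and kept the phenyl ring, whereas this one also replaces that ring with a pyridine ring carrying chlorine and leaves out the furan ring. No measured evidence bears on why the reading stays the same.

With all four compounds level, nothing shown identifies a group that moves this read-out at the concentration tested. On these data alone, whether a carboxylic acid or an amine on the ring, or a longer alkyl chain in place of the aromatic group on this nitrogen, would read differently remains open.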